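This account rests on a few compounds, and the source may have more. Where it says the series, first, only, none or still open, it means among the compounds named here.

Measured so far:
compound 1 `COc1ccc(S(N)(=O)=O)cc1C(=O)Nc1cccc(-c2nncn2C(C)C)n1`: 7%
compound 2 `COc1cc(C)c(S(N)(=O)=O)cc1C(=O)Nc1cccc(-c2nncn2C(C)C)n1`: -3%

In an assay for inhibition of Rho-associated protein kinase 1 (Homo sapiens), tested at 1 uM (a higher number here means more inhibition at the concentration tested (going by the name of the read-out), a lower number less inhibition), compound 1 gives 7%. Compound 2 gives -3%, and the step of a number 10 percentage points lower from compound 1 to compound 2 (within the scatter) lies within the scatter, so the two compounds are not separated on this read-out.

Compound 3 is `COc1ccc(S(C)(=O)=O)cc1C(=O)Nc1cccc(-c2nncn2C(C)C)n1`. It differs from compound 1 by methyl in place of amino on a sulfonyl sulfur. Within the data shown here, no measured step touches the sulfonyl sulfur; the single step recorded, a number 10 percentage points lower from compound 1 to compound 2 (within the scatter), concerns a different change and stays within the scatter. A step of a number 2 percentage points lower from compound 1 to compound 3 (within the scatter) is therefore expected, none beyond the scatter. Compound 3 is estimated at 5%, with a range from -10% to 20%.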

Compound 3, a percentage reported as inhibition, at one concentration (the size of the read-out at that concentration, not a potency): 1%
Compound 3: middle estimate off by 4 percentage points, on the high side; the measured number falls inside the stated range.
By their numbers in this assay, from the lowest: compounds 2, 3 and 1 (each within the scatter of the next).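

At the sulfonyl sulfur, the first change tested at this place, a number 6 percentage points lower from compound 1 to compound 3 (within the scatter) in this assay, so swapping sulfamoyl for methylsulfonyl does not separate the two compounds. Losing the amino group and its hydrogen-bond donor therefore leaves no readable mark on this read-out, where all three compounds lie within the scatter of one another. Nothing available bears on why this is so.

Open, from the compounds shown here alone, is whether an ethyl or a dimethylamino group on the sulfonyl sulfur would move the number beyond the scatter. A carboxylic acid in place of the whole sulfonyl group is equally untested here.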